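A few compounds are considered here, and "the series" means these few. Any claim that something is new, unique, unknown or untested is made for them only; others in the source may bear on it.

Of the compounds shown here, two have so far been measured in an assay on isolated protein for binding affinity to Equilibrative nucleoside transporter 1 (Homo sapiens); a higher number here means a weaker inhibitor, a lower number a stronger inhibitor. Compound 1 `OC[C@H]1O[C@@H](n2cnc3c(SCCCc4ccccc4)ncnc32)[C@H](O)[C@@H]1O` gives 1350 nM in this assay. Among the measured compounds shown here, compound 2 `Cc1ccc(CSc2ncnc3c2ncn3[C@@H]2O[C@H](CO)[C@@H](O)[C@H]2O)cc1` gives 457 nM in this assay, the lower of the two numbers; the only measured step, a 3.0-fold lower number from compound 1 to compound 2 (0.47 log units; beyond the scatter), came from putting 4-methylphenyl in place of phenethyl on a saturated chain carbon bound to a sulfur. Compound 3 `OC[C@H]1O[C@@H](n2cnc3c(CSc4cccc(Br)c4)ncnc32)[C@H](O)[C@@H]1O` has not yet been measured. It differs from compound 2 by ((3-bromophenyl)sulfanyl)methyl in place of (4-methylbenzyl)sulfanyl on an aromatic carbon. For the measured compounds named here, only that single step bears on this change, and it altered a different part of the side group, so it gives little guidance on moving the sulfur and exchanging a methyl for a bromine. No step beyond the usual scatter is firmly expected, with the expected step being a 1.5-fold higher number from compound 2 to compound 3 (0.19 log units; within the scatter). Compound 3 is therefore estimated at 700 nM in this assay, with a range from 150 nM to 3000 nM.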

Compound 3, half-maximal inhibitory concentration: 363 nM
Compound 3: the middle estimate sits 1.9-fold (0.29 log units) above what was measured; low and high end bracket the measured number.
By their numbers in this assay, from the lowest: compounds 3 and 2 (each within the scatter of the next); then compound 1.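

In this assay, putting ((3-bromophenyl)sulfanyl)methyl in place of (4-methylbenzyl)sulfanyl gives a 1.3-fold lower number from compound 2 to compound 3 (0.10 log units; within the scatter), so this measurement does not separate the two side groups. The earlier step changed the group on the sulfur, whereas this one shows that the number can stay within the scatter when the atom bound to the aromatic carbon changes from sulfur to carbon and the ring substituent changes from methyl to bromine. No available evidence accounts for this result.

On these data alone, the sulfur placement and the ring substituent changed together, so the contribution of each remains open, as they may have offset each other or both had little effect. Also open, as far as these compounds go, is how the number would respond to an amine or a carboxylic acid on the benzene ring, or to an oxygen in place of the sulfur.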